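The compounds below may be only part of what the source reports. "The series", "measured", "known", "first", "only" and "open" are said of these compounds alone.

Compounds measured so far:

compound 1 `CC(=O)O[C@@H]1[C@H](OC/C2=C/[C@@H]3[C@@H](C(C)C)CC=C(C)[C@@H]3C[C@H](OC(=O)/C=C/c3cn(C)cn3)[C@]3(C)C=C[C@@]2(OCCO)O3)OC[C@@H](O)[C@H]1O` gives 20 nM
compound 2 `CCO[C@]12C=C[C@](C)(O1)[C@@H](OC(=O)/C=C/c1cn(C)cn1)C[C@H]1C(CO)=CC[C@H](C(C)C)[C@H]1/C=C\2CO[C@@H]1OC[C@@H](O)[C@@H](O)[C@@H]1OC(C)=O` gives 20 nM
compound 3 `CO[C@]12CC[C@](C)(O1)[C@@H](OC(=O)/C=C/c1cn(C)cn1)C[C@@H]1[C@H](/C=C\2CO[C@@H]2OC[C@@H](O)[C@@H](O)[C@@H]2OC(C)=O)[C@@H](C(C)C)CC[C@@H]1C` gives 200 nM

In a functional assay on MCF7 cells (Homo sapiens), read by ELISA, with a stated time of 20 h (on this read-out lower numbers stand for stronger inhibition and higher numbers for weaker inhibition), compound 1 gives 20 nM and compound 2 gives 20 nM; these two values sit within the scatter of each other, so no order between them can be stated. Compound 3 gives 200 nM in this assay, the highest of the three numbers, and its gap to both compound 1 and compound 2 lies beyond the scatter, so compound 3 is the weakest inhibitor of the three.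

The unmeasured compound 4 `CO[C@]12CC[C@](C)(O1)[C@@H](OC(=O)CCc1cn(C)cn1)C[C@@H]1[C@H](/C=C\2CO[C@@H]2OC[C@@H](O)[C@@H](O)[C@@H]2OC(C)=O)[C@@H](C(C)C)CC[C@@H]1C` differs from compound 3 in one place:

2-(1-methyl-1H-imidazol-4-yl)ethyl in place of 2-(1-methyl-1H-imidazol-4-yl)ethenyl on a carbonyl carbon

Among the compounds with values here, no pair of measured compounds differs by a single change, so the size of this step cannot be read off the existing data. Compound 1, compound 2 and compound 3 all carry the 2-(1-methyl-1H-imidazol-4-yl)ethenyl group, and nothing is known about what its removal does. The step from compound 3 to compound 4 in this assay is therefore expected to be small, a 1.5-fold higher number from compound 3 to compound 4 (0.18 log units; within the scatter), and is as likely to lie within the scatter as just beyond it toward a higher number. Compound 4 is estimated to give 300 nM in this assay, with a range from 100 nM to 1000 nM.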

Compound 4, half-maximal inhibitory concentration: > 10000 nM
Compound 4: no number, only a limit; the forecaster's own chance of this, stated with the estimate: 5%; middle value at least 33-fold (1.52 log units) away from the limit.
By their numbers in this assay, from the lowest: compounds 1 and 2 (each within the scatter of the next); then compound 3. At a limit, above all of these: compound 4.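

In this assay, within the data shown here, 2-(1-methyl-1H-imidazol-4-yl)ethyl in place of 2-(1-methyl-1H-imidazol-4-yl)ethenyl on a carbonyl carbon brings an at least 50-fold higher number from compound 3 to compound 4 (1.69 log units; beyond the scatter), a large step and the first single change that can be read. Among these compounds, the value of compound 4 is a limit of the assay and not a number, so the true size of the step stays unknown: the limit of > 10000 nM in this assay, at which 1 of the 4 values shown sits. The earlier compounds all carried the ethenyl group and could say nothing about this position, whereas the change now shows that the read-out depends strongly on it, although the two groups match in heavy atoms, ring, donors and acceptors and differ in the count only by the one double bond outside aromatic rings.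

The compounds shown leave open whether a triple bond in this chain, a longer chain, or a phenyl ring in place of the 1-methyl-1H-imidazol-4-yl ring would keep a measurable value in this assay. They also leave open whether the same change would bring a step of similar size on the cores of compound 1 and compound 2.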